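The source may hold more compounds than are shown below. What is called first, only, known or untested is meant among the compounds shown, and "the series" means these compounds.

Measured in an ADME assay on BJ cells (Homo sapiens), read by MTT assay, with a stated time of 72 h; a higher number here means a weaker inhibitor, a lower number a stronger inhibitor:
Compound 1 `Nc1nc(N)c2c(-c3cc4ccccc4o3)cn([C@@H]3O[C@H](CO)[C@@H](O)[C@H]3O)c2n1`: > 100000 nM
Compound 2 `Cc1nc(N)c2c(-c3ccsc3)cn([C@@H]3O[C@H](CO)[C@@H](O)[C@H]3O)c2n1`: > 100000 nM

Both readings are limits of the assay and not exact numbers. Compound 2 gives > 100000 nM, which is a limit. It therefore sits with compound 1 at the limit of > 100000 nM in this assay, at which 2 of the 2 values shown sit.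

Compound 3 `Cc1nc(N)c2c(-c3cc4ccccc4o3)cn([C@@H]3O[C@H](CO)[C@@H](O)[C@H]3O)c2n1` has not yet been measured. It differs from compound 2 in a single place: 1-benzofuran-2-yl in place of thiophen-3-yl on an aromatic carbon.

Within the data shown here, no measured pair shows what such a swap does on its own. However, compound 1 already carries the 1-benzofuran-2-yl group, and its reading in this assay is also a limit, > 100000 nM. No step beyond the scatter is therefore expected, and any real shift would most likely be towards stronger inhibition. The expected step, a number no higher from compound 2 to compound 3 (the limit leaves the size open), is close to nil. For compound 3 the estimated value is 100000 nM, with an expected range of 30000 nM to 150000 nM.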

Compound 3, half-maximal inhibitory concentration: > 100000 nM
Compound 3: only a limit was reported (the forecaster's own chance of this, stated with the estimate: 85%); the middle value lies on the limit itself.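

Compound 3 also gives only a limit of the assay, > 100000 nM, so no step can be read from compound 1 or compound 2 to compound 3. The compounds shown leave open whether either swap, 1-benzofuran-2-yl for thiophen-3-yl or methyl for amino, changes the true value in this assay at all.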